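Hexyloxy in place of cyclopropylamino: cytotoxicity outlook

The compounds below may be only part of what the source reports. "The series", "measured", "known", "first", "only" and "open" are said of these compounds alone.

compound 1, `Nc1nc(NC2CC2)c2ncn(/C=C3/CC3(CO)CO)c2n1`: 71500 nM
compound 2, `CCCOc1nc(N)nc2c1ncn2/C=C1/CC1(CO)CO`: > 20000 nM

Going by the values given here, compound 1 `Nc1nc(NC2CC2)c2ncn(/C=C3/CC3(CO)CO)c2n1` is the only compound of the set with a number in an ADME assay on BCBL1 cells (Homo sapiens) for cytotoxicity, with a stated time of 7 days; a lower number here means that less compound is tolerated, a higher number that more compound is tolerated; in that assay compound 1 gives 71500 nM. For compound 2 `CCCOc1nc(N)nc2c1ncn2/C=C1/CC1(CO)CO` the assay reports only a limit, > 20000 nM. Among the compounds with values here, the one measured step is a step that the limit leaves unreadable from compound 1 to compound 2, which cannot be read because of the limit of > 20000 nM in this assay, at which 1 of the 2 values shown sits.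

Compound 3 `CCCCCCOc1nc(N)nc2c1ncn2/C=C1/CC1(CO)CO` differs from compound 1 in one place: hexyloxy in place of cyclopropylamino on an aromatic carbon. No readable measured step bears on this change, so the expectation rests on compound 1 alone. For compound 3 the step of a 1.4-fold lower number from compound 1 to compound 3 (0.16 log units; within the scatter) is expected to stay within the usual scatter, with a wide range to reflect the missing evidence. Compound 3 is estimated at 50000 nM, in the range 15000 nM to 150000 nM.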

Compound 3, half-maximal cytotoxic concentration: > 20000 nM
Compound 3 ended at the assay's limit; the forecaster's own chance of this, stated with the estimate: 35%; the middle value is on the limit's open side.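

In this assay compound 3 gives only a limit, > 20000 nM. Going by these compounds alone, no step from compound 1 or compound 2 to compound 3 can be read because of such limits: the limit of > 20000 nM in this assay, at which 2 of the 3 values shown sit. The compounds shown leave open whether cyclopropylamino, propoxy and hexyloxy differ at all in this assay.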